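A few compounds are considered here, and "the series" means these few. Any claim that something is new, unique, unknown or untested is made for them only; others in the source may bear on it.

Compound 1 `O=C(Nc1cccc(-n2cc(-c3ccncc3)c(-c3cc(O)cc(Cl)c3)n2)c1)Nc1ccc(Cl)c(C(F)(F)F)c1` gives 96%
Compound 2 `COc1cc(Cl)cc(-c2nn(-c3cccc(NC(=O)Nc4cc(C(F)(F)F)cc(C(F)(F)F)c4)c3)cc2-c2ccncc2)c1` gives 13%

In a functional assay on NCI-H460 cells (Homo sapiens) for inhibition, read by sulforhodamine B assay, with a stated time of 48 h, tested at 1 uM (on this read-out lower numbers stand for a stronger effect and higher numbers for a weaker effect at the one concentration tested), compound 1 gives 96%, whereas compound 2 gives 13%. Compound 2 thus shows the lower of the two numbers, and its nearest neighbour, compound 1, stands a long way higher, beyond the scatter; the two compounds differ in more than one place, so only the two values themselves can be read, not a single step.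

Compound 3 `COc1cc(Cl)cc(-c2nn(-c3cccc(NC(=O)Nc4cccc(C(F)(F)F)c4)c3)cc2-c2ccncc2)c1` has not yet been measured in this assay . It differs from compound 2 by hydrogen in place of trifluoromethyl on an aromatic carbon. For the measured compounds named here, no single-point step between measured compounds is known here, so the size of this change can only be anticipated. Compound 1, which carries one trifluoromethyl group and gives 96%, suggests that a ring with fewer such groups may give a higher number, but it also carries other differences.

For compound 3 a move upward from compound 2 is expected, of the size a number 32 percentage points higher from compound 2 to compound 3 (beyond the scatter). The estimate for compound 3 is 45%, with a range from 15% to 85%.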

Compound 3, a percentage reported as activity, at one concentration (the size of the read-out at that concentration, not a potency): 45%
For compound 3 middle estimate and measured number coincide at the digits printed, and the stated range covers the measured number.
By their numbers in this assay, from the lowest: compound 2; then compound 3; then compound 1.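

In this assay, for the compounds shown here, hydrogen in place of trifluoromethyl on an aromatic carbon of the six-membered aromatic ring of carbon only gives a number 32 percentage points higher from compound 2 to compound 3 (beyond the scatter), the first change in this set that can be read at a single place. This position is therefore not indifferent: within this pair, the stronger effect at the one concentration tested goes with the trifluoromethyl group being present, while compound 3, which keeps the other trifluoromethyl group on that ring, still gives 45%. No measurement of any property of the two compounds is available to account for the step.

The compounds shown leave open whether a nitrile or an amine on the same aromatic carbon would bring the number closer to that of compound 2 or to that of compound 3. Going by these compounds alone, they also leave open how the remaining gap up to compound 1 divides among its differences from compound 3, since no single-place step separates those two compounds.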